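The source may report more compounds than this note shows. Statements on the series, on what has been measured and on what is new or still open speak of the compounds shown alone.

Among the compounds with values here, in a functional assay on HepG2 cells (Homo sapiens) for antiproliferative activity, read by MTT assay, with a stated time of 48 h (on this read-out higher numbers stand for weaker inhibition and lower numbers for stronger inhibition), compound 1 `CC(=O)N1N=C(c2ccc3ccccc3c2)OC1c1ccccc1Br` gives 3.98 ug/mL, the lower of the two numbers measured so far, while compound 2 `CC(=O)N1N=C(c2ccc3ccccc3c2)OC1c1ccccc1Cl` gives 4.32 ug/mL; the step of a 1.1-fold higher number from compound 1 to compound 2 (0.04 log units; within the scatter) falls within the scatter. Compound 3 `CC(=O)N1N=C(c2ccc3ccccc3c2)OC1c1ccccc1O` differs from compound 1 by hydroxy in place of bromo on an aromatic carbon. Within the data shown here, the one measured step exchanges one halogen for another and does not speak to a hydroxy entering, so no measured step bears directly on this change. With nothing to anchor a larger shift, compound 3 is expected to give roughly 5.5 ug/mL, within 2 ug/mL to 16 ug/mL. That estimate means an expected step of a 1.4-fold higher number from compound 1 to compound 3 (0.14 log units; within the scatter).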

Compound 3, half-maximal inhibitory concentration: 1.84 ug/mL
Estimate against measurement, compound 3: 3.0-fold (0.48 log units) above; measured number outside the range, below it.
By their numbers in this assay, from the lowest: compound 3; then compounds 1 and 2 (each within the scatter of the next).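

In this assay the aromatic carbon ortho to a large group turns out to respond to what sits on it: hydroxy in place of bromo gives a 2.2-fold lower number from compound 1 to compound 3 (0.34 log units; beyond the scatter) and hydroxy in place of chloro gives a 2.3-fold lower number from compound 2 to compound 3 (0.37 log units; beyond the scatter) while exchanging one halogen for the other did not move the number beyond the scatter. Both new steps are modest, but they show that this place is not indifferent to every change. Nothing available explains this shift. As far as these compounds go, it remains open whether methoxy or an amine at this place would also give a lower number, which would help show what the hydroxy's hydrogen contributes.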